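The source may report more compounds than this note shows. Statements on the series, on what has been measured and on what is new or still open speak of the compounds shown alone.

Compound 3 `CC(C)[C@H](NS(=O)(=O)c1cccc(C(=O)NO)c1)C(=O)Nc1ccccc1` carries the highest number of the three measured in an ADME assay on isolated protein for inhibition of protein deacetylase HDAC6 (Homo sapiens), read by fluorescence, with stated times of 5 min and 30 min (a higher number here means a weaker inhibitor, a lower number a stronger inhibitor), where compound 3 gives 40500 nM. Nearest is compound 1 `C[C@H](NS(=O)(=O)c1cccc(C(=O)NO)c1)C(=O)Nc1ccccc1`, which in this assay gives 27700 nM; the step of a 1.5-fold higher number from compound 1 to compound 3 (0.16 log units; within the scatter) lies within the scatter. Furthest is compound 2 `O=C(NO)c1cccc(S(=O)(=O)Nc2ccccc2)c1`, which in this assay gives 1500 nM, a number far below that of compound 3 and beyond the scatter. Compound 4 `O=C(NO)c1cccc(S(=O)(=O)N[C@H](C(=O)Nc2ccccc2)c2ccccc2)c1` is not yet measured and differs from compound 3 by phenyl in place of isopropyl on a saturated chain carbon bound to a carbonyl carbon and a sulfonamide nitrogen. Among the compounds with values here, the only measured step at this same carbon is a 1.5-fold higher number from compound 1 to compound 3 (0.16 log units; within the scatter), and it left the number essentially unchanged. Phenyl is larger than either methyl or isopropyl, but nothing measured shows how far a ring at this carbon moves the number, and compound 2 gives no guide to a change at this carbon. The expectation for compound 4 in this assay is therefore a step of a 1.1-fold higher number from compound 3 to compound 4 (0.05 log units; within the scatter), not beyond the scatter. Compound 4 is thus estimated at 45000 nM, with a range from 15000 nM to 130000 nM.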

Compound 4, half-maximal inhibitory concentration: 6700 nM
Compound 4: the middle estimate sits 6.7-fold (0.83 log units) above what was measured, outside the stated range (below it).
By their numbers in this assay, from the lowest: compound 2; then compound 4; then compounds 1 and 3 (each within the scatter of the next).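

In this assay, the saturated chain carbon bound to a carbonyl carbon and a sulfonamide nitrogen proves sensitive to the group it carries: phenyl in place of isopropyl gives a 6.0-fold lower number from compound 3 to compound 4 (0.78 log units; beyond the scatter), and phenyl in place of methyl gives a 4.1-fold lower number from compound 1 to compound 4 (0.62 log units; beyond the scatter). The earlier comparison of the two open-chain groups, a 1.5-fold higher number from compound 1 to compound 3 (0.16 log units; within the scatter), showed no such response, so among these three groups only phenyl sets itself apart at this carbon. Nothing available explains why the number falls with phenyl at this carbon.

On these data alone, whether the lower number depends on an aromatic ring or would also follow from a saturated ring remains open, and cyclohexyl at this carbon would separate the two. Benzyl at the same carbon would show whether the ring must be attached directly.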